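Ester side chain variation in a cytotoxicity series

This account rests on a few compounds, and the source may have more. Where it says the series, first, only, none or still open, it means among the compounds named here.

Measured so far in a functional assay on DU-145 cells (Homo sapiens) for cytotoxicity, read by MTT assay; a higher number here means a weaker inhibitor, a lower number a stronger inhibitor:
compound 1 `CC(=O)OCCO[C@H](CC=C(C)C)C1=CC(=O)c2c(O)ccc(O)c2C1=O`: 15500 nM
compound 2 `CC(C)=CC[C@@H](OC[C@H](C)O)C1=CC(=O)c2c(O)ccc(O)c2C1=O`: 24500 nM
compound 3 `CCCC(O)CC(=O)O[C@H](CC=C(C)C)C1=CC(=O)c2c(O)ccc(O)c2C1=O`: > 100000 nM, a limit of the assay rather than a number

Within the data shown here, compound 3 is the one compound that sits at the limit of > 100000 nM in this assay, at which 1 of the 3 values shown sits. Between the other two, a 1.6-fold higher number from compound 1 to compound 2 (0.20 log units; within the scatter). The two steps into the ester both weaken: an at least 6.4-fold higher number from compound 1 to compound 3 (0.80 log units; beyond the scatter) and an at least 4.0-fold higher number from compound 2 to compound 3 (0.61 log units; beyond the scatter).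

Compound 4 `CC(C)=CC[C@@H](OC(=O)C1CCCOC1)C1=CC(=O)c2c(O)ccc(O)c2C1=O` differs from compound 3 in one place: oxan-3-yl in place of 2-hydroxypentyl on a carbonyl carbon. Among the measured compounds shown here, no measured step changes the acyl group of an ester, so none bears directly on this change; the steps from compound 1 and compound 2 into compound 3 show only that the ester carrying the 2-hydroxypentyl group lies beyond the limit. Compound 4 keeps the ester and is expected to remain weak, with the step estimated at an at least 1.4-fold lower number from compound 3 to compound 4 (0.15 log units; that floor lies within the scatter). For compound 4 the estimate in this assay is 70000 nM, with a range from 25000 nM to 200000 nM, and a fair chance that again only a limit is reported.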

Compound 4, half-maximal inhibitory concentration: 29700 nM
Beside the measured number, compound 4's estimate is 2.4-fold (0.37 log units) above it, within the range that was stated.
By their numbers in this assay, from the lowest: compounds 1, 2 and 4 (each within the scatter of the next). At a limit, above all of these: compound 3.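

In this assay, the ester link alone does not put a compound out of range: oxan-3-yl in place of 2-hydroxypentyl on the carbonyl carbon gives an at least 3.3-fold lower number from compound 3 to compound 4 (0.52 log units; beyond the scatter). With this ring, the ester reads level with the compounds carrying 2-hydroxypropyl and 2-acetoxyethyl on the same oxygen, with a 1.2-fold higher number from compound 2 to compound 4 (0.08 log units; within the scatter) and a 1.9-fold higher number from compound 1 to compound 4 (0.28 log units; within the scatter), so the acyl group, and not the ester as such, sets compound 3 apart. Compound 3 remains the only compound at a limit of the assay: the limit of > 100000 nM in this assay, at which 1 of the 4 values shown sits.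

The change replaces an open chain with a ring and removes the hydroxyl donor in a single step, and the compounds shown do not separate these two differences. A plain pentyl chain or a cyclohexyl ring on the same carbonyl carbon would bear on that question.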